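Moving the fluorine on the anilide ring of compound 1

This account rests on a few compounds, and the source may have more. Where it says the series, first, only, none or still open, it means among the compounds named here.

Measured compounds:
- compound 1, `CC1=C(/C=C/C(C)=C/C=C/C(C)=C\C(=O)Nc2ccc(F)cc2)C(C)(C)CCC1n1ccnc1`, 25100 nM
- compound 2, `CC1=C(/C=C/C(C)=C/C=C/C(C)=C\C(=O)Nc2ccccc2)C(C)(C)CCC1n1ccnc1`, 1730 nM
- compound 3, `CC1=C(/C=C/C(C)=C/C=C/C(C)=C\C(=O)Nc2ccccc2)C(C)(C)CC=C1c1cncnc1`, 31000 nM

In a functional assay on SK-BR-3 cells (Homo sapiens) for inhibition, read by MTT assay (a lower number here means a stronger inhibitor of growth, a higher number a weaker inhibitor of growth), compound 1 gives 25100 nM, the second highest of the three numbers. Its nearest neighbour is compound 3 at 31000 nM, a gap within the scatter; furthest from it is compound 2 at 1730 nM. Within the data shown here, the one step that touches compound 1 is a 15-fold lower number from compound 1 to compound 2 (1.16 log units; beyond the scatter), a large change for a small edit on the anilide ring.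

Compound 4, `CC1=C(/C=C/C(C)=C/C=C/C(C)=C\C(=O)Nc2cccc(F)c2)C(C)(C)CCC1n1ccnc1`, differs from compound 1 by 3-fluorophenyl in place of 4-fluorophenyl on an amide-type nitrogen. Among the measured compounds shown here, no measured pair shows the fluorine simply moved from one ring position to another, so the step to compound 4 has no direct precedent. The step to compound 2 shows that removing the fluorine from that position brings the number down sharply; keeping a fluorine but at the new position is taken here to land somewhere between compound 1 and compound 2, with wide uncertainty. Compound 4 is therefore expected to give about 8000 nM, in the range 2000 nM to 32000 nM, which would mean an estimated step of a 3.1-fold lower number from compound 1 to compound 4 (0.50 log units; beyond the scatter).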

Compound 4, concentration for 50% growth inhibition: 17000 nM
Estimate against measurement, compound 4: 2.1-fold (0.33 log units) below, and the stated range covers the measured number.
By their numbers in this assay, from the lowest: compound 2; then compounds 4, 1 and 3 (each within the scatter of the next).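

In this assay, moving the fluorine on the anilide ring gives a 1.5-fold lower number from compound 1 to compound 4 (0.17 log units; within the scatter) and so makes no difference beyond the scatter: 3-fluorophenyl and 4-fluorophenyl on the amide-type nitrogen cannot be told apart here. Fluoro in place of hydrogen at the new position gives a 9.8-fold higher number from compound 2 to compound 4 (0.99 log units; beyond the scatter) and so shows that the higher number is not confined to a fluoro at one ring position; among the compounds sharing the core of compound 1, only compound 2, which has no fluorine, stands apart. Nothing shown here gives a reason for this.

From the compounds shown here alone, whether a chloro or a methoxy group on the anilide ring would track the fluoro compounds or compound 2 remains open. So does whether a fluoro would have the same effect on the anilide ring of compound 3.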